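Fluorine on the Fused Ring and Vero Cell Cytotoxicity

The compounds below may be only part of what the source reports. "The series", "measured", "known", "first", "only" and "open" are said of these compounds alone.

Four compounds built on a shared core were compared for their effect on cell viability. Compound 1 `CO/N=C1\C(=O)N(CN2CCN(c3c(F)cc4c(=O)c(C(=O)O)cn(C5CC5)c4c3OC)CC2)c2ccccc21` was tested in an ADME assay on Vero cells (Chlorocebus sabaeus) for cytotoxicity, read by MTT assay, with a stated time of 72 h (on this read-out lower numbers stand for higher toxicity in this test and higher numbers for lower toxicity in this test), where compound 1 gives 76500 nM. Compound 2 `CO/N=C1\C(=O)N(CN2CCN(c3c(F)cc4c(=O)c(C(=O)O)cn(C5CC5)c4c3OC)CC2)c2ccc(F)cc21` differs from compound 1 in one place: fluoro in place of hydrogen on an aromatic carbon In this assay compound 2 gives 46800 nM. The step of a 1.6-fold lower number from compound 1 to compound 2 (0.21 log units; within the scatter) is therefore too small to be read as a real change.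

Compound 3 `CO/N=C1\C(=O)N(CCN2CCN(c3c(F)cc4c(=O)c(C(=O)O)cn(C5CC5)c4c3OC)CC2)c2ccccc21` differs from compound 1 in its core; how the two cores differ is not broken down here. In this assay compound 3 gives 306000 nM, the highest number among the three measured compounds, and its distance from both compound 1 and compound 2 lies beyond the scatter.

Compound 4 `CO/N=C1\C(=O)N(CCN2CCN(c3c(F)cc4c(=O)c(C(=O)O)cn(C5CC5)c4c3OC)CC2)c2ccc(F)cc21` has not yet been measured. It stands to compound 3 exactly as compound 2 stands to compound 1: fluoro in place of hydrogen on an aromatic carbon The place of the entering fluoro is described in the same words for both pairs, so this is the same change, made twice among the compounds shown.

Among the measured compounds shown here, because a 1.6-fold lower number from compound 1 to compound 2 (0.21 log units; within the scatter) lies within the scatter, an equally small step is expected here, a 1.6-fold lower number from compound 3 to compound 4 (0.21 log units; within the scatter), there being nothing among the measured compounds to suggest a larger one. Compound 4 is accordingly estimated at 190000 nM, with a likely range from 80000 nM to 450000 nM.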

Compound 4, half-maximal cytotoxic concentration: 12800 nM
The estimate for compound 4 lay 15-fold (1.17 log units) above the measured number, and the stated range ends above it.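

In this assay the entering fluoro gives a 24-fold lower number from compound 3 to compound 4 (1.38 log units; beyond the scatter), a large step on the core of compound 3 where the same change on the core of compound 1 gave no readable one. Set side by side, the two steps show that the size of this change did not carry over from one core to the other in this series: the same change on two cores in this assay, a 1.6-fold lower number (0.21 log units; within the scatter) from compound 1 to compound 2 and a 24-fold lower number (1.38 log units; beyond the scatter) from compound 3 to compound 4, 15-fold (1.17 log units) apart, beyond the scatter of two such steps. This shows only that the outcome of the fluoro depends on the core it is placed on, for this one pair of cores; it does not show which part of the cores accounts for the gap or why, and, since the earlier step lies within the scatter, it does not establish a shared direction or give a rule for predicting the step on any further core.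

Going by these compounds, whether a chloro group, a nitrile or an amine on the same aromatic carbon would follow the fluoro on either core remains open. Also open, on these data alone, is whether a core carrying a longer chain would show a step as large as the one on the core of compound 3, or one as small as that on the core of compound 1.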